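This account rests on a few compounds, and the source may have more. Where it says the series, first, only, none or still open, it means among the compounds named here.

Measured compounds in an assay on brain (strain C57BL6) for displacement of a labelled ligand from AP2-associated protein kinase 1 (Mus musculus), read by scintillation counting, with a stated time of 1 h; on this read-out higher numbers stand for weaker inhibition and lower numbers for stronger inhibition:
- compound 1 `CC(=O)Nc1cc(-c2ccc(OC[C@@H](N)CC(C)C)c(F)c2)ccn1`: 0.52 nM
- compound 2 `CC(=O)Nc1cc(-c2ccc(OC[C@@H](N)CC(C)C)c(Cl)c2)ccn1`: 0.06 nM
- compound 3 `CC(=O)Nc1cc(-c2ccc(OC[C@@H](N)CC(C)C)cc2)ccn1`: 0.9 nM

Compound 3 stands at the highest of the three numbers. Its nearest neighbour is compound 1, the step being a 1.7-fold higher number from compound 1 to compound 3 (0.24 log units; within the scatter). The wider gap is a 15-fold higher number from compound 2 to compound 3 (1.18 log units; beyond the scatter). The remaining measured step, an 8.7-fold lower number from compound 1 to compound 2 (0.94 log units; beyond the scatter), also concerns only the halogen on the aromatic carbon.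

Compound 4 `CC(C)C[C@H](N)COc1ccc(-c2ccnc(N)c2)cc1` differs from compound 3 in one place: hydrogen in place of acetyl on a nitrogen on an aromatic ring. None of the three measured steps touches the acetyl on the ring nitrogen; all of them vary the substituent on the aromatic carbon of the other ring. Among the measured compounds shown here, no measured step therefore bears on this change, and the expectation can rest only on the value of compound 3 and on the absence of any precedent. The working assumption is that removing the acetyl is not neutral, and the step expected in this assay is a 6.7-fold higher number from compound 3 to compound 4 (0.82 log units; beyond the scatter), in the direction of a higher number, with a wide range to reflect the lack of an anchoring step. Compound 4 is thus estimated at 6 nM, with a range from 0.6 nM to 60 nM.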

Compound 4, inhibition constant: 13 nM
The estimate for compound 4 lay 2.2-fold (0.34 log units) below the measured number, within the range that was stated.
By their numbers in this assay, from the lowest: compound 2; then compounds 1 and 3 (each within the scatter of the next); then compound 4.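

Among the compounds shown here, the first change at the acetamido group gives a 14-fold higher number from compound 3 to compound 4 (1.16 log units; beyond the scatter) in this assay, so on this read-out the acetyl on the nitrogen is not a neutral part of the compound, and going from acetamido to amino weakens inhibition. For the compounds shown here, this step and a 15-fold higher number from compound 2 to compound 3 (1.18 log units; beyond the scatter) are both printed as large, so the series now has two places where a single change moves the number beyond the scatter, whereas the earlier steps concerned only the halogen on the aromatic carbon. Nothing at hand speaks to what lies behind the new step.

The compounds shown carry only acetamido or amino on this nitrogen, so it remains open whether a propionyl, a formyl or a methanesulfonyl group there would stay near the acetyl compounds or fall toward the amino compound. Also open, going by these compounds, is whether the step from hydrogen to chloro on the aromatic carbon, seen with the acetyl in place, would hold in the amino compound, which carries hydrogen at that carbon.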